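Compound 3 and a change of configuration

A few compounds are considered here, and "the series" means these few. Any claim that something is new, unique, unknown or untested is made for them only; others in the source may bear on it.

Measured in a functional assay for inhibition, with Rattus norvegicus as the target; on this read-out lower numbers stand for stronger inhibition and higher numbers for weaker inhibition:
- Compound 1 `CCC(C)/N=c1\c(O)c(O)\c1=N/c1ccc(C#N)cc1`: 2100 nM
- Compound 2 `CC(C)/N=c1\c(O)c(O)\c1=N/c1ccc(C#N)cc1`: 13700 nM
- Compound 3 `C[C@@H](/N=c1\c(O)c(O)\c1=N/c1ccc(C#N)cc1)c1ccccc1`: 56 nM

Compound 3 has the lowest number of the three, and so the strongest inhibition so far. Compound 4 `C[C@H](/N=c1\c(O)c(O)\c1=N/c1ccc(C#N)cc1)c1ccccc1` differs from it as follows: the two compounds have the same atoms and bonds and differ only in configuration as drawn: 1 of 3 stereo elements differ; a stereocentre at a saturated chain carbon is drawn R in compound 3 and S in compound 4. Among the compounds with values here, no measured step changes configuration alone, so none gauges this directly. The nearest evidence concerns the group on the double-bonded nitrogen: a 240-fold lower number from compound 2 to compound 3 (2.39 log units; beyond the scatter) and a 38-fold lower number from compound 1 to compound 3 (1.57 log units; beyond the scatter), both large, and a 6.5-fold higher number from compound 1 to compound 2 (0.81 log units; beyond the scatter), modest. In this assay, a step beyond the scatter towards a higher number is therefore expected, though its size is uncertain. The expected step is an 11-fold higher number from compound 3 to compound 4 (1.03 log units; beyond the scatter). For compound 4 the estimated value is 600 nM, with an expected range of 70 nM to 5000 nM.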

Compound 4, half-maximal inhibitory concentration: > 30000 nM
Compound 4: no number, only a limit; the forecaster's own chance of this, stated with the estimate: 5%; middle value at least 50-fold (1.69 log units) from the limit.
By their numbers in this assay, from the lowest: compound 3; then compound 1; then compound 2. At a limit, above all of these: compound 4.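

In this assay compound 4 gives > 30000 nM, which is a limit of the assay and not a number. The stereocentre at the saturated chain carbon proves decisive in its own right, with a large step (an at least 530-fold higher number from compound 3 to compound 4 (2.72 log units; beyond the scatter)) that rests on configuration alone: the fact that compounds 3 and 4 differ only in the configuration as drawn. The 1-phenylethyl group therefore gives the lower number only as drawn R, since as drawn S the number rises instead (an at least 2.1-fold higher number from compound 2 to compound 4 (0.34 log units; beyond the scatter); an at least 14-fold higher number from compound 1 to compound 4 (1.15 log units; beyond the scatter)).

From the compounds shown here alone, how far the step runs past the limit remains open. So does whether configuration at this carbon matters as much with a 1-cyclohexylethyl group on the double-bonded nitrogen.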